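This account rests on a few compounds, and the source may have more. Where it says the series, first, only, none or still open, it means among the compounds named here.

Three compounds share one core and differ only in the group on one aromatic carbon. Compound 1 `Cc1nc2c(OCc3ccccc3)cccn2c1N` gives 99% in a functional assay on the whole organism with Rattus norvegicus as the target, at a dose of 40 mg/kg by the intraperitoneal route; a higher number here means more inhibition at the dose given (going by the name of the read-out), a lower number less inhibition. Compound 2 `Nc1cnc2c(OCc3ccccc3)cccn12` gives 32%, and compound 3 `CC(C)c1nc2c(OCc3ccccc3)cccn2c1N` gives 0%. Compound 3 therefore stands lowest of the three measured numbers, with compound 2 nearest and compound 1 furthest away. Among the measured compounds shown here, the steps so far all run downward as the group on that carbon grows: a number 67 percentage points lower from compound 1 to compound 2 (beyond the scatter), a number 99 percentage points lower from compound 1 to compound 3 (beyond the scatter) and a number 32 percentage points lower from compound 2 to compound 3 (beyond the scatter).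

Compound 4 `CC(C)(C)c1nc2c(OCc3ccccc3)cccn2c1N` is not yet measured. It differs from compound 3 by methyl in place of hydrogen on a saturated chain carbon bound to an aromatic carbon and two saturated chain carbons. The steps from compound 1 to compound 3 and from compound 2 to compound 3 both bear on this change, since each enlarges the same group and each lowered inhibition by a large amount. Compound 3 already shows no inhibition, so further growth of the group can hardly push the number lower. For compound 4 the expected step is therefore a number 3 percentage points higher from compound 3 to compound 4 (within the scatter), none beyond the scatter, and the estimate for compound 4 in this assay is 3%, within a range from 0% to 15%.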

Compound 4, a percentage reported as inhibition, in the whole organism at one dose (the size of the read-out at that dose, not a potency): 0%
The estimate for compound 4 lay 3 percentage points above the measured number, within the range that was stated.
By their numbers in this assay, from the lowest: compounds 3 and 4 (each within the scatter of the next); then compound 2; then compound 1.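

In this assay, isopropyl to tert-butyl gives no change at the digits printed from compound 3 to compound 4 (within the scatter), so this position has reached the floor of the read-out, and the read-out cannot tell these two branched groups apart. Tert-butyl also gives a number 99 percentage points lower from compound 1 to compound 4 (beyond the scatter) and a number 32 percentage points lower from compound 2 to compound 4 (beyond the scatter), steps of the same size as those to isopropyl, so among these four compounds only methyl reaches high inhibition, while hydrogen and both branched groups fall well short of it. Nothing measured here explains why the number drops with these groups or why methyl stands above hydrogen.

The compounds shown leave open whether an ethyl group, the nearest straight chain after methyl, would keep the inhibition of compound 1 or lose it. Results at one dose also leave open whether compound 3 and compound 4 would differ at another dose.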